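Removing One Methyl Group from Compound 1

A few compounds are considered here, and "the series" means these few. Any claim that something is new, unique, unknown or untested is made for them only; others in the source may bear on it.

Compound 1 `CC(=O)N1CCN(c2ccc(Nc3nccc(-c4nn(C)c5ccccc45)n3)cc2)CC1` gives 181 nM
Compound 2 `CC(=O)N1CCCN(c2cccc(Nc3nccc(-c4c[nH]c5cccnc45)n3)c2)CC1` gives 688 nM
Compound 3 `CC(=O)N1CCN(c2ccc(Nc3ncc(C#N)c(-c4c[nH]c5ccccc45)n3)cc2)CC1` gives 4 nM

In a functional assay on MV4-11 cells (Homo sapiens) for antiproliferative activity, read by resazurin assay, with a stated time of 72 h (a lower number here means a stronger inhibitor of growth, a higher number a weaker inhibitor of growth), compound 1 stands in the middle of the three, with a lower number than compound 2 and a higher number than compound 3, both gaps beyond the scatter. Compound 4 `CC(=O)N1CCN(c2ccc(Nc3nccc(-c4n[nH]c5ccccc45)n3)cc2)CC1` has not yet been measured. It keeps the core of compound 1 but has hydrogen in place of methyl on an aromatic nitrogen, so that 1-methyl-1H-indazol-3-yl becomes 1H-indazol-3-yl (hydrogen in place of methyl on an aromatic nitrogen). For the measured compounds named here, no measured pair isolates this change. Compound 3 carries hydrogen on an aromatic nitrogen and gives 4 nM, but compound 2 also carries one and gives 688 nM, and both differ from compound 1 elsewhere too. A modest move toward stronger growth inhibition is therefore expected, with wide uncertainty. The expected change is a 2.3-fold lower number from compound 1 to compound 4 (0.35 log units; beyond the scatter). For compound 4 the estimated value is 80 nM, with an expected range from 20 nM to 350 nM.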

Compound 4, concentration for 50% growth inhibition: 346 nM
Beside the measured number, compound 4's estimate is 4.3-fold (0.64 log units) below it, within the range that was stated.
By their numbers in this assay, from the lowest: compound 3; then compounds 1, 4 and 2 (each within the scatter of the next, the first and the last beyond it).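

For the compounds shown here, with hydrogen in place of methyl on the aromatic nitrogen, this assay gives a 1.9-fold higher number from compound 1 to compound 4 (0.28 log units; within the scatter), and this pair is the first to isolate the change. On the core of compound 1, the assay therefore does not separate 1-methyl-1H-indazol-3-yl from 1H-indazol-3-yl, so neither the methyl nor the hydrogen on this nitrogen can be said to set the level of growth inhibition. Nothing shown gives a reason for this result.

On these data alone, it remains open whether a longer chain such as ethyl, or a chain ending in an amine, on this same nitrogen would also stay within the scatter of these two compounds. Also open, as far as these compounds go, is whether the same exchange would read alike on a core carrying a nitrile.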